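The source may hold more compounds than are shown below. What is called first, only, known or untested is meant among the compounds shown, and "the series" means these compounds.

Measured so far:
Compound 1, `CN(C)c1ccc(-c2cc(C(=O)c3ccccc3)c(N)s2)cc1`, gives 29% in an assay on CHO cells for positive allosteric modulation of adenosine receptor A1 (Homo sapiens), read by ERK phosphorylation, tested at 10 uM; a higher number here means a weaker effect of the compound at the concentration tested, a lower number a stronger effect.
Compound 2, `COc1ccc(-c2cc(C(=O)c3ccc(Cl)cc3)c(N)s2)cc1`, gives 29% in this assay.

On these numbers compound 2 stands level with compound 1; the two values fall within the scatter of each other, so no order between them can be read. Compound 3, `CN(C)c1ccc(-c2cc(C(=O)c3ccc(Cl)cc3)c(N)s2)cc1`, is not yet measured. It differs from compound 2 by dimethylamino in place of methoxy on an aromatic carbon. Within the data shown here, no single step between measured compounds covers this change. Since compound 1, which already carries dimethylamino, gives 29%, the step of a number 1 percentage points higher from compound 2 to compound 3 (within the scatter) is expected to stay within the scatter, in no clear direction. Compound 3 is therefore expected to give 30%, between 15% and 45%.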

Compound 3, a percentage reported as activity, at one concentration (the size of the read-out at that concentration, not a potency): 41%
Compound 3: middle estimate off by 11 percentage points, on the low side; low and high end bracket the measured number.
By their numbers in this assay, from the lowest: compounds 1 and 2 (each within the scatter of the next); then compound 3.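

In this assay, dimethylamino in place of methoxy on an aromatic carbon, para to a large group, gives a number 12 percentage points higher from compound 2 to compound 3 (beyond the scatter) and so a weaker effect at the concentration tested, which shows that this position is not indifferent to the group it carries. Chloro in place of hydrogen on an aromatic carbon, with dimethylamino kept, gives a number 12 percentage points higher from compound 1 to compound 3 (beyond the scatter) and also weakens the effect. Nothing measured here explains either step. From the compounds shown here alone, how a free amine or an ethoxy group would behave at the first position remains open, and so does how fluoro or bromo would compare with chloro.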